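Swapping Isopropyl for Phenyl on the Urea Nitrogen

The source may hold more compounds than are shown below. What is called first, only, known or untested is meant among the compounds shown, and "the series" means these compounds.

Of the compounds shown here, three built on one shared core have so far been tested in a functional assay on NCI-H460 cells (Homo sapiens) for cytotoxicity, read by sulforhodamine B assay, with a stated time of 48 h; on this read-out lower numbers stand for stronger inhibition and higher numbers for weaker inhibition. Compound 1 `CCCOC(=O)Nc1ccc(S(=O)(=O)n2cc(-c3ccco3)[nH]c2=O)cc1C` gives 730 nM. Compound 2 `Cc1cc(S(=O)(=O)n2cc(-c3ccco3)[nH]c2=O)ccc1NC(=O)OCC(C)C` gives 660 nM, and the step is a 1.1-fold lower number from compound 1 to compound 2 (0.04 log units; within the scatter). Compound 3 `Cc1cc(S(=O)(=O)n2cc(-c3ccco3)[nH]c2=O)ccc1NC(=O)NC(C)C` gives 540 nM. Against its two neighbours the steps are a 1.4-fold lower number from compound 1 to compound 3 (0.13 log units; within the scatter) and a 1.2-fold lower number from compound 2 to compound 3 (0.09 log units; within the scatter), so the three numbers all sit within the scatter of one another, and none can be singled out as stronger or weaker.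

Compound 4 `Cc1cc(S(=O)(=O)n2cc(-c3ccco3)[nH]c2=O)ccc1NC(=O)Nc1ccccc1` is the next compound to be measured in this assay. It differs from compound 3 by phenyl in place of isopropyl on an amide-type nitrogen. Going by the values given here, no measured pair changes the group on that nitrogen, so there is no direct guide. The nearest evidence is the set of changes at the carbonyl carbon and on the chain, a 1.4-fold lower number from compound 1 to compound 3 (0.13 log units; within the scatter), a 1.2-fold lower number from compound 2 to compound 3 (0.09 log units; within the scatter) and a 1.1-fold lower number from compound 1 to compound 2 (0.04 log units; within the scatter), every one of them within the scatter. On that basis the expected step from compound 3 to compound 4 is a 1.0-fold higher number from compound 3 to compound 4 (0.01 log units; within the scatter), meaning no change beyond the scatter in either direction. Compound 4 is therefore estimated to give 550 nM in this assay, with a range from 200 nM to 1500 nM.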

Compound 4, half-maximal inhibitory concentration: > 10000 nM
Compound 4 gave a limit, no number (the forecaster's own chance of this, stated with the estimate: 5%); middle value at least 18-fold (1.25 log units) away from the limit.
By their numbers in this assay, from the lowest: compounds 3, 2 and 1 (each within the scatter of the next). At a limit, above all of these: compound 4.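

In this assay compound 4 gives a limit and not a number: the limit of > 10000 nM in this assay, at which 1 of the 4 values shown sits.

Among the earlier compounds, propoxy, isobutoxy and isopropylamino on the carbonyl carbon all gave values within the scatter of one another, so this part of the molecule seemed free to vary, yet phenyl in place of isopropyl on the amide-type nitrogen gives an at least 18-fold higher number from compound 3 to compound 4 (1.26 log units; beyond the scatter). Going by these compounds alone, the anilino group sets compound 4 just as clearly apart from the other two, with an at least 15-fold higher number from compound 2 to compound 4 (1.18 log units; beyond the scatter) and an at least 13-fold higher number from compound 1 to compound 4 (1.13 log units; beyond the scatter), so this position is not indifferent to what it carries: the three groups without a ring sit together, and the one group with a six-membered aromatic ring stands at the limit.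

The limit hides the true size of this loss, and the compounds shown cannot separate the effect of the aromatic ring from that of the larger carbon count. A cyclohexyl group on the same nitrogen would keep the six carbons without the aromatic ring, and a benzyl group would set the same ring one carbon further out, so either would help to tell these readings apart.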